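Moving the methyl on the sulfonyl side chain

The source may hold more compounds than are shown below. What is called first, only, known or untested is meant among the compounds shown, and "the series" means these compounds.

Measured so far:
Compound 1 `N#Cc1cc2c(nc1N1CCC(C(=O)NS(=O)(=O)Cc3ccccc3)CC1)CCC(F)C2=O` — 255000 nM
Compound 2 `CC(c1ccccc1)S(=O)(=O)NC(=O)C1CCN(c2nc3c(cc2C#N)C(=O)OC3)CC1` — 4160 nM

Both compounds were tested in a functional assay (Platelet, plasma) for inhibition, with Homo sapiens as the target; on this read-out lower numbers stand for stronger inhibition and higher numbers for weaker inhibition. Of the two numbers, compound 2 gives the lower one, at 4160 nM, while compound 1 gives 255000 nM; the two compounds differ in their cores as well as in their side chains, so the gap between them is simply what the two values show.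

Compound 3 `Cc1ccc(CS(=O)(=O)NC(=O)C2CCN(c3nc4c(cc3C#N)C(=O)OC4)CC2)cc1` keeps the core of compound 2 and alters only the group on the sulfonyl sulfur: 4-methylbenzyl in place of 1-phenylethyl on a sulfonyl sulfur. The same atoms are present, joined differently, and neither group brings a donor, an acceptor or a charge.

Among the compounds with values here, no step between measured compounds is known that isolates such a change, so the expectation rests on compound 2 alone. The step from compound 2 to compound 3 is expected to be small, a 1.1-fold higher number from compound 2 to compound 3 (0.03 log units; within the scatter), and may well lie within the scatter. Compound 3 is therefore estimated at 4500 nM, with a likely range from 1500 nM to 14000 nM.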

Compound 3, half-maximal inhibitory concentration: 4280 nM
For compound 3 the middle estimate is 1.1-fold (0.02 log units) above the measured one, and the stated range covers the measured number.
By their numbers in this assay, from the lowest: compounds 2 and 3 (each within the scatter of the next); then compound 1.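

Exchanging 1-phenylethyl for 4-methylbenzyl on a sulfonyl sulfur gives a 1.0-fold higher number from compound 2 to compound 3 (0.01 log units; within the scatter) in this assay, so on the shared core these two arrangements of the same atoms cannot be told apart on this read-out. Within the data shown here, the earlier compounds could not show this, since compound 1 and compound 2 differ in their cores as well as in their side chains, and this is the first step that changes only the group at this position. It shows that the methyl can sit in either of these two places without a change that rises above the scatter, though that holds only for this pair on this core, and nothing at hand says why the two groups read alike.

The compounds shown leave open whether a carboxylic acid or an amine carried on the aromatic ring, or a longer chain in place of 4-methylbenzyl, would move the number beyond the scatter. They also leave open whether the same exchange would read the same way on the core of compound 1.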